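Cytotoxicity limits and the step to compound 4

This account rests on a few compounds, and the source may have more. Where it says the series, first, only, none or still open, it means among the compounds named here.

Measured so far in a toxicity assay on Huh-7 cells (Homo sapiens) for cytotoxicity, read by CCK-8 assay, with a stated time of 24 h (a lower number here means that less compound is tolerated, a higher number that more compound is tolerated), for three compounds:
compound 1 `O=c1cc(-c2ccc(Nc3ccc(F)cc3)cc2)oc2cc(O)c(O)c(O)c12` gives > 100000 nM
compound 2 `COc1c(OC)c(OC)c2c(=O)cc(-c3ccccc3)oc2c1-c1ccc(OC(F)(F)F)cc1` gives > 100000 nM
compound 3 `Cc1ccc(-c2c(O)c(O)c(O)c3c(=O)cc(-c4ccccc4)oc23)cc1` gives > 100000 nM

Compound 1 gives > 100000 nM as its entry, and this is a limit of the assay, not a number. For the measured compounds named here, the series so far stands at the limit of > 100000 nM in this assay, at which 3 of the 3 values shown sit, and offers no numerical value. Going by the values given here, no pair of measured compounds differs in one place, so no measured step is available for comparison.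

Compound 4 `CN1CCN(c2ccc(-c3cc(=O)c4c(O)c(O)c(O)cc4o3)cc2)CC1` keeps the core of compound 1 and changes one group (4-methylpiperazin-1-yl in place of (4-fluorophenyl)amino on an aromatic carbon). 4-methylpiperazin-1-yl takes the place of (4-fluorophenyl)amino on an aromatic carbon, para to a large group.

Given the limit of compound 1 (> 100000 nM) no step beyond the scatter is expected in this assay and no direction is favoured. The expected change is a number no higher from compound 1 to compound 4 (the limit leaves the size open) and it is only an estimate. Compound 4 is expected near 100000 nM in an estimated range from 30000 nM to 300000 nM and may also return only a limit.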

Compound 4, half-maximal cytotoxic concentration: > 100000 nM
Compound 4: only a limit was reported; the forecaster's own chance of this, stated with the estimate: 70%; the middle value sits exactly at the limit.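

No new step can be read: compound 1 and compound 4 both return only a limit in this assay. The compounds shown leave open the concentration at which any of them reaches half-maximal cytotoxicity, and whether exchanging (4-fluorophenyl)amino for 4-methylpiperazin-1-yl changes it, with the series at: the limit of > 100000 nM in this assay, at which 4 of the 4 values shown sit.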